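The compounds below may be only part of what the source reports. "The series", "measured", "known", "first", "only" and "open" are said of these compounds alone.

In a functional assay on HOP-62 cells (Homo sapiens) for inhibition, read by sulforhodamine B assay (on this read-out lower numbers stand for stronger inhibition of growth and higher numbers for weaker inhibition of growth), compound 2 (`FC(F)(F)c1ccc(-c2ccc(-c3ccc(-c4nc5ccccc5[nH]4)cc3)cc2)cc1`) stands highest of the two measured compounds at 100000 nM and compound 1 (`Cc1ccc2[nH]c(-c3ccc(-c4ccc(-c5cccc(Cl)c5)cc4)cc3)nc2c1`) gives 2740 nM in the same read-out. Compound 1 lies well below compound 2, and that gap lies beyond the scatter. Compound 3 (`Oc1ccc(-c2ccc(-c3ccc(-c4nc5ccccc5[nH]4)cc3)cc2)cc1`) departs from compound 2 by one change (hydroxy in place of trifluoromethyl on an aromatic carbon) with hydroxy in place of trifluoromethyl on an aromatic carbon. For the measured compounds named here, no measured pair differs in one place. A step to a lower number beyond the scatter is expected, since compound 1 gives 2740 nM without any trifluoromethyl. The estimated step (a 13-fold lower number from compound 2 to compound 3 (1.10 log units; beyond the scatter)) is therefore uncertain in size. Compound 3 is expected at an estimated 8000 nM (range 1500 nM to 60000 nM).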

Compound 3, concentration for 50% growth inhibition: 47200 nM
Compound 3: middle estimate off by 5.9-fold (0.77 log units), on the low side, within the range that was stated.
By their numbers in this assay, from the lowest: compound 1; then compound 3; then compound 2.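

In this assay, hydroxy in place of trifluoromethyl on an aromatic carbon para to a large group gives a 2.1-fold lower number from compound 2 to compound 3 (0.33 log units; beyond the scatter) and so shows that this position responds to the change, though only modestly. The change brings in a hydrogen-bond donor and a hydrogen-bond acceptor, but no measurement shown accounts for the step. From the compounds shown here alone, whether an amine, a carboxylic acid or a methoxy group at this position would move the number further remains open. So does whether the same change would have a similar effect on the core of compound 1.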